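Hydroxy for Methyl on a Weak Antagonist Series

A few compounds are considered here, and "the series" means these few. Any claim that something is new, unique, unknown or untested is made for them only; others in the source may bear on it.

Compound 2, with the structure `CC(C)Cn1cnc2ncnc(N)c21`, is tested in a functional assay on CHO cells for antagonist activity at adenosine receptor A2b (Homo sapiens); on this read-out lower numbers stand for stronger inhibition and higher numbers for weaker inhibition. In this assay compound 2 gives > 30000 nM, and this value is a limit of the assay rather than a number. Compound 1, with the structure `CCC(C)n1cnc2ncnc(N)c21`, gives > 30000 nM in this assay, again a limit. The difference between them, isobutyl in place of sec-butyl on an aromatic nitrogen, therefore yields a step that the two limits leave unreadable from compound 1 to compound 2. Compound 3, with the structure `Nc1ncnc2c1ncn2C1CCC1`, gives 17000 nM in this assay. Compounds 1 and 2 stand at the limit of > 30000 nM in this assay, at which 2 of the 3 values shown sit, so nothing further can be read from setting compound 3 beside them.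

Compound 4, with the structure `CC(O)Cn1cnc2ncnc(N)c21`, differs from compound 2 by hydroxy in place of methyl on a saturated chain carbon bound to two saturated chain carbons. Among the compounds with values here, none of the measured steps involve a hydroxy group, so no measured step bears directly on this change. With compound 2 sitting at a limit, only weak inhibition can be expected of compound 4, with a step that the limit leaves unreadable from compound 2 to compound 4 and an estimate of 40000 nM within the range from 12000 nM to 120000 nM.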

Compound 4, inhibition constant: > 30000 nM
Compound 4 ended at the assay's limit (the forecaster's own chance of this, stated with the estimate: 70%); the middle value is on the limit's open side.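

In this assay compound 4 gives > 30000 nM, a limit of the assay and not a number, so neither step to it, from compound 1 or from compound 2, can be read: the limit of > 30000 nM in this assay, at which 3 of the 4 values shown sit.

The compounds shown leave open whether hydroxy in place of methyl changes inhibition at all.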